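A Pyrazole in Place of a Dichlorophenyl Group

The source may hold more compounds than are shown below. What is called first, only, known or untested is meant among the compounds shown, and "the series" means these compounds.

Within the data shown here, in a physicochemical assay for lipophilicity, using the shake flask method (on this read-out lower numbers stand for lower lipophilicity and higher numbers for higher lipophilicity), compound 1 (`C[C@H](Oc1ccc2ncc(/C=C/C(=O)O)c(C3CC3)c2c1)c1c(Cl)cccc1Cl`) gives 3.7 as the lower of the two numbers measured so far. The other measured compound, compound 2 (`C[C@H](Oc1ccc2ncc(/C=C/c3nn[nH]n3)c(C3CC3)c2c1)c1c(Cl)cccc1Cl`), gives 4.3 in this assay and carries 2H-tetrazol-5-yl in place of carboxy on a double-bonded chain carbon bound to a double-bonded chain carbon. That step is modest and beyond the scatter (a number 0.60 log units higher from compound 1 to compound 2 (beyond the scatter)).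

Compound 3 (`Cc1cnn(C)c1[C@H](C)Oc1ccc2ncc(/C=C/C(=O)O)c(C3CC3)c2c1`) keeps the carboxy group and changes elsewhere, with 1,4-dimethyl-1H-pyrazol-5-yl in place of 2,6-dichlorophenyl on a saturated chain carbon bound to an oxygen on an aromatic ring and a saturated chain carbon. Among the measured compounds shown here, no measured step touches this place, so the tetrazole step gives no direct measure of it, and the expectation rests on the structural change alone. A downward move larger than the tetrazole step and beyond the scatter is expected, and the estimated step is a number 1.50 log units lower from compound 1 to compound 3 (beyond the scatter) in this assay for this exchange. Compound 3 is expected at 2.2 (estimated range 1.6 to 2.8).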

Compound 3, distribution coefficient: 0.9
Beside the measured number, compound 3's estimate is 1.30 log units above it; measured number below the stated range.
By their numbers in this assay, from the lowest: compound 3; then compound 1; then compound 2.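

In this assay the exchange of 2,6-dichlorophenyl for 1,4-dimethyl-1H-pyrazol-5-yl gives a number 2.80 log units lower from compound 1 to compound 3 (beyond the scatter) and is graded large. Among these compounds, the only earlier step, the exchange of carboxy for 2H-tetrazol-5-yl, gives a number 0.60 log units higher from compound 1 to compound 2 (beyond the scatter) and is graded modest, so the group on the saturated chain carbon moves this number further than that exchange does, and in the opposite direction. The entering group also differs from the leaving one in carrying hydrogen-bond acceptors and no chlorine, yet the data contain no measurement that singles out which of these differences accounts for the step.

The compounds shown leave open whether the same exchange would give a step of similar size on the compound that carries 2H-tetrazol-5-yl, since the two exchanges are never seen together in one compound. They also leave open how much of the step belongs to the chlorine atoms and how much to the ring itself, a question that a plain phenyl or a pyridine ring on the same saturated chain carbon would bear on.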